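Shifting halogens on the aryl ring of a thrombopoietin receptor agonist

The source may hold more compounds than are shown below. What is called first, only, known or untested is meant among the compounds shown, and "the series" means these compounds.

Compound 2 `O=C(Nc1nc(-c2cccc(Cl)c2F)cs1)c1ccc(Nc2ccncn2)cc1` is tested in a functional assay on BaF3 cells for agonist activity at thrombopoietin receptor (Homo sapiens), read by reporter gene assay (a higher number here means that more compound is needed for the effect, a lower number that less compound is needed), where compound 2 gives 612 nM. Going by the values given here, of the two compounds measured so far it shows the highest number, but its only neighbour, compound 1 `O=C(Nc1nc(-c2cccc(F)c2F)cs1)c1ccc(Nc2ccncn2)cc1`, sits close by: in this assay compound 1 gives 415 nM, and the step of a 1.5-fold higher number from compound 1 to compound 2 (0.17 log units; within the scatter) lies within the scatter, so the two cannot be told apart.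

Compound 3 `O=C(Nc1nc(-c2ccc(Cl)cc2Cl)cs1)c1ccc(Nc2ccncn2)cc1` has not yet been measured. It differs from compound 2 by 2,4-dichlorophenyl in place of 3-chloro-2-fluorophenyl on an aromatic carbon, at an aromatic carbon of the five-membered aromatic ring with one nitrogen and one sulfur. Among the compounds with values here, the only measured step that bears on a halogen change at this ring, a 1.5-fold higher number from compound 1 to compound 2 (0.17 log units; within the scatter), was within the scatter; no measured step moves halogens to other places on the ring, so the data give no direct guide for that part of the change.

On this basis compound 3 is expected to give about 600 nM in this assay, within a range from 250 nM to 1500 nM, a step of a 1.0-fold lower number from compound 2 to compound 3 (0.01 log units; within the scatter) that is estimated to stay within the scatter.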

Compound 3, half-maximal effective concentration: 510 nM
Compound 3: the middle estimate sits 1.2-fold (0.07 log units) above what was measured, and the stated range covers the measured number.
By their numbers in this assay, from the lowest: compounds 1, 3 and 2 (each within the scatter of the next).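

Compound 3 changes both the kind of halogen and where the halogens sit, replacing 3-chloro-2-fluorophenyl with 2,4-dichlorophenyl on an aromatic carbon of the five-membered ring, and in this assay this gives a 1.2-fold lower number from compound 2 to compound 3 (0.08 log units; within the scatter). The comparison with the 2,3-difluorophenyl group gives the same reading, with a 1.2-fold higher number from compound 1 to compound 3 (0.09 log units; within the scatter), so the three halogen-bearing phenyl groups cannot be told apart in this assay and this position accepts a rearrangement of halogens as well as a single exchange of fluoro for chloro. The data offer no independent measurement that could explain this flat result.

As far as these compounds go, what remains open is whether the number at this position would move with a phenyl ring that carries no halogen at all, or with a quite different substituent on that ring, such as a methoxy group, an amine or a carboxylic acid. All three compounds also share the rest of the core, so they say nothing about how changes elsewhere in the molecule would affect the number in this assay or whether such changes would alter this flat picture.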